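The source may hold more compounds than are shown below. What is called first, only, known or untested is meant among the compounds shown, and "the series" means these compounds.

Compound 1 `COc1cc2c(Oc3ccc(NS(=O)(=O)c4ccccc4OC(F)(F)F)cc3F)ccnc2cc1OCCCN1CCN(C)CC1`: 103 nM
Compound 2 `COc1cc2c(Oc3ccc(NS(=O)(=O)c4cc(F)ccc4F)cc3F)ccnc2cc1OCCCN1CCN(C)CC1`: 158 nM
Compound 3 `COc1cc2c(Oc3ccc(NS(=O)(=O)c4c(F)cccc4F)cc3F)ccnc2cc1OCCCN1CCN(C)CC1`: 156 nM

These values come from a functional assay on MDA-MB-231 cells (Homo sapiens) for inhibition, with a stated time of 5 h; a lower number here means a stronger inhibitor, a higher number a weaker inhibitor. Compound 2 , at 158 nM, stands within the scatter of both neighbours: a 1.0-fold lower number from compound 2 to compound 3 (0.01 log units; within the scatter) and a 1.5-fold higher number from compound 1 to compound 2 (0.19 log units; within the scatter). Compound 4 `COc1cc2c(Oc3ccc(NS(=O)(=O)c4cc(F)ccc4F)cc3F)ccnc2cc1OCCCN1CCCC(C)C1` departs from compound 2 in one place: 3-methylpiperidin-1-yl in place of 4-methylpiperazin-1-yl on a saturated chain carbon, three bonds along the chain from an oxygen on an aromatic ring, on a saturated chain carbon, three bonds along the chain from an oxygen on an aromatic ring. For the measured compounds named here, no measured step touches this place. All three, including a 1.5-fold higher number from compound 1 to compound 3 (0.18 log units; within the scatter), exchange the group on the sulfonyl sulfur, so they give no size for this change. No step beyond the scatter is therefore expected in this assay, though with wide uncertainty. The expected step is a 1.2-fold higher number from compound 2 to compound 4 (0.08 log units; within the scatter). For compound 4 the estimated value is 190 nM, with an expected range of 70 nM to 500 nM.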

Compound 4, half-maximal inhibitory concentration in the MDA-MB-231 assay: 185 nM
Beside the measured number, compound 4's estimate is 1.0-fold (0.01 log units) above it, and the stated range covers the measured number.
By their numbers in the MDA-MB-231 assay, from the lowest: compounds 1, 3, 2 and 4 (each within the scatter of the next).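

For the compounds shown here, in the MDA-MB-231 assay, the first change at this position, on a saturated chain carbon, gives a 1.2-fold higher number from compound 2 to compound 4 (0.07 log units; within the scatter), so this assay does not separate 3-methylpiperidin-1-yl from 4-methylpiperazin-1-yl. In a physicochemical assay for solubility, read by HPLC, with a stated time of 24 h, at pH 7.4 (a higher number here means a more soluble compound, a lower number a less soluble compound), compound 2 gives 68800 nM and compound 4 gives 18000 nM in the same read-out. In the physicochemical assay, the same exchange does separate the two compounds: the measured solubility of compound 2, 68800 nM, and of compound 4, 18000 nM, a 3.8-fold lower number (0.58 log units; beyond the scatter)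

The compounds shown leave open how a morpholin-4-yl or an unsubstituted piperidin-1-yl group at this place would read in either assay. They also leave open whether the same exchange gives similar steps when 2-(trifluoromethoxy)phenyl sits on the sulfonyl sulfur.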